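The source may report more compounds than this note shows. Statements on the series, on what has been measured and on what is new or still open speak of the compounds shown alone.

Three esters of one shared polyether core have been measured in a functional assay on HeLa cells (Homo sapiens) for inhibition, read by sulforhodamine B assay, with a stated time of 48 h; a higher number here means a weaker inhibitor of growth, a lower number a stronger inhibitor of growth. Compound 1 `O=C(CCCCC1CCCCC1)OCC1COCCOCCOCCOCCO1` is reported only as a limit, > 100000 nM, in this assay. Compound 2 `CC(C)=CC1C(C(=O)OCC2COCCOCCOCCOCCOCCO2)C1(C)C` gives 63000 nM, and compound 3 `O=C(OCC1COCCOCCOCCOCCOCCO1)c1cccc(-c2ccc(Br)cc2)c1` gives 7800 nM. Of the two numbers, compound 2 holds the higher, and its gap to compound 3 lies beyond the usual scatter. Compound 4 `CC(=O)OCC1COCCOCCOCCOCCOCCO1` differs from compound 2 by methyl in place of 2,2-dimethyl-3-(2-methylprop-1-en-1-yl)cyclopropyl on a carbonyl carbon. Within the data shown here, no measured pair shows such a change, so the step from compound 2 to compound 4 is estimated at a 1.9-fold higher number from compound 2 to compound 4 (0.28 log units; within the scatter), toward weaker growth inhibition. Compound 4 is expected to give 120000 nM, within a range of 40000 nM to 400000 nM, and may well return only a limit.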

Compound 4, concentration for 50% growth inhibition: > 100000 nM
Compound 4 gave a limit, no number (the forecaster's own chance of this, stated with the estimate: 55%); the middle value does not contradict the limit.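

Replacing the 2,2-dimethyl-3-(2-methylprop-1-en-1-yl)cyclopropyl group with methyl on a carbonyl carbon gives the first step that can be read among these esters: an at least 1.5-fold higher number from compound 2 to compound 4 (0.20 log units; that floor lies within the scatter). As far as these compounds go, its full size stays unknown, because compound 4 gave a limit and not a number: the limit of > 100000 nM in this assay, at which 2 of the 4 values shown sit. The step therefore does not show whether this change weakens growth inhibition beyond the scatter.

Still open, from the compounds shown here alone, is how a group of intermediate size, such as ethyl, would behave at this carbonyl carbon. An aminomethyl group there also remains untested in the compounds shown.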